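This account rests on a few compounds, and the source may have more. Where it says the series, first, only, none or still open, it means among the compounds named here.

Among the compounds with values here, compound 1 `CCCCC(=O)N1CCC(c2cc(OC)ccc2N)=N1` sits at the bottom of the three numbers measured so far: in an assay on isolated protein for inhibition of Nitric oxide synthase, inducible (Homo sapiens), with a stated time of 30 min, tested at 1 mM (a higher number here means more inhibition at the concentration tested (going by the name of the read-out), a lower number less inhibition), compound 1 gives 0.18%, while compound 2 `Nc1cc(Cl)c(Cl)cc1C1=NN(C(=O)C2CC2)CC1` gives 15.5% and compound 3 `Nc1cc(Cl)c(Cl)cc1C1=NN(C(=O)c2ccccc2)CC1` gives 36.1%. Within the data shown here, the only measured step on the amide side of the shared core is the one from compound 2 to compound 3, a number 20.6 percentage points higher from compound 2 to compound 3 (beyond the scatter). Compound 4 `COc1ccc(N)c(C2=NN(C(=O)CCc3ccccc3)CC2)c1` differs from compound 1 by phenyl in place of ethyl on a saturated chain carbon, two bonds along the chain from a carbonyl carbon, an aromatic ring entering on the chain rather than on the carbonyl carbon itself. That step bears only loosely on the new one, so a modest rise is expected, a number 7.8 percentage points higher from compound 1 to compound 4 (within the scatter), from a very low base. The estimate for compound 4 in this assay is therefore 8%, with a range from 0% to 25%.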

Compound 4, a percentage reported as inhibition, at one concentration (the size of the read-out at that concentration, not a potency): 21.2%
For compound 4 the middle estimate is 13.2 percentage points below the measured one, and the stated range covers the measured number.
By their numbers in this assay, from the lowest: compound 1; then compounds 2 and 4 (each within the scatter of the next); then compound 3.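

Phenyl in place of ethyl on a saturated chain carbon, two bonds along the chain from a carbonyl carbon, gives a number 21 percentage points higher from compound 1 to compound 4 (beyond the scatter) in this assay from a very low base. The earlier step of a number 20.6 percentage points higher from compound 2 to compound 3 (beyond the scatter) placed the phenyl on the carbonyl carbon itself, whereas this one shows a rise with the ring out on the chain. Nothing available explains this rise.

Still open, from the compounds shown here alone, is how the number moves with a shorter benzyl link or a longer chain. Going by these compounds, an amine or a carboxylic acid on the phenyl ring of compound 4 is equally open.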